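The compounds below may be only part of what the source reports. "The series", "measured", "known", "first", "only" and "open" are said of these compounds alone.

For the measured compounds named here, compound 2 `O=C1/C(=C/c2ccccc2)CCC/C1=C\c1cccc([N+](=O)[O-])c1` is one of two compounds already measured here, and it is the one that yields a number. Going by the values given here, in a functional assay on HSC-2 cells (Homo sapiens) for cytotoxicity, with a stated time of 24 h (a higher number here means that more compound is tolerated, a lower number that less compound is tolerated), compound 2 gives 3700 nM, the only number among the values shown. Compound 1 `CN(C)c1ccc(/C=C2\CCC/C(=C\c3ccccc3[N+](=O)[O-])C2=O)cc1` in this assay gives > 400000 nM, which is a limit of the assay and not a number. That limit is the limit of > 400000 nM in this assay, at which 1 of the 2 values shown sits, where one of the two values stands.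

Compound 3 `CN(C)c1ccc(/C=C2\CCC/C(=C\c3cccc([N+](=O)[O-])c3)C2=O)cc1` has not yet been measured in this assay. It differs from compound 2 in one place: dimethylamino in place of hydrogen on an aromatic carbon. No step between two measured compounds is shown that would isolate what this change does on its own, so any expectation rests on the two values above. Among the compounds with values here, compound 1 is the only measured compound that carries a dimethylamino group, and it is the one that sits at the limit. On that basis the step in this assay is expected to be an 11-fold higher number from compound 2 to compound 3 (1.03 log units; beyond the scatter), towards more compound being tolerated and beyond the usual scatter. Compound 3 is therefore estimated at 40000 nM, within a range from 6000 nM to 400000 nM.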

Compound 3, half-maximal cytotoxic concentration: 32000 nM
Beside the measured number, compound 3's estimate is 1.3-fold (0.10 log units) above it; low and high end bracket the measured number.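

In this assay, the change from phenyl to 4-(dimethylamino)phenyl can now be read on its own, with the 3-nitrophenyl group held constant: an 8.6-fold higher number from compound 2 to compound 3 (0.94 log units; beyond the scatter) shows that dimethylamino in place of hydrogen, para to a large group, goes with more compound being tolerated. The second step, an at least 12-fold lower number from compound 1 to compound 3 (1.09 log units; beyond the scatter), keeps the dimethylamino group and changes only 2-nitrophenyl to 3-nitrophenyl, so the place of the nitro group also matters here and the dimethylamino group does not set the number alone. The size of that second step is only a lower bound, since the value of compound 1 is a limit of the assay and not a number: the limit of > 400000 nM in this assay, at which 1 of the 3 values shown sits.

For the compounds shown here, it remains open whether the dimethylamino step would have the same size on a compound carrying 2-nitrophenyl, since only one pair shows this change. From the compounds shown here alone, it is also open whether a different group at the same place, such as methoxy, a primary amine or a diethylamino group with its longer chains, would shift the number in the same direction.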